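The compounds below may be only part of what the source reports. "The series", "measured", "known", "first", "only" and "open" are said of these compounds alone.

Of the compounds shown here, two from this series have been tested in a functional assay on COLO 205 cells (Homo sapiens) for inhibition, read by sulforhodamine B assay, with a stated time of 48 h, tested at 1 uM; on this read-out lower numbers stand for a stronger effect and higher numbers for a weaker effect at the one concentration tested. Compound 1 `COc1cc(Cl)cc(-c2nn(-c3cccc(NC(=O)Nc4cccc(C(F)(F)F)c4)c3)cc2-c2ccncc2)c1` gives 79% in this assay, while compound 2 `O=C(Nc1cccc(-n2cc(-c3ccncc3)c(-c3cc(O)cc(Cl)c3)n2)c1)Nc1ccc(Cl)c(Cl)c1` gives 101%. Compound 2 therefore stands at the higher end of the two numbers, meaning the weaker effect, and its nearest neighbour on the scale, compound 1, sits lower by an amount beyond the usual scatter. Compound 3 `COc1cc(Cl)cc(-c2nn(-c3cccc(NC(=O)Nc4ccc(Cl)c(Cl)c4)c3)cc2-c2ccncc2)c1` has not yet been measured. It differs from compound 2 in one place: methyl in place of hydrogen on an oxygen on an aromatic ring, that is, hydroxy becomes methoxy on the 3-chloro-5-hydroxyphenyl group, giving 3-chloro-5-methoxyphenyl. Within the data shown here, no pair of measured compounds shows this change on its own, so the size of the step cannot be read directly from the data. Compound 1, which carries the methoxy, gives 79%, which hints that compound 3 may lie somewhat below compound 2. The expected step in this assay from compound 2 to compound 3 is therefore a number 11 percentage points lower from compound 2 to compound 3 (beyond the scatter), a modest lowering that may not clear the scatter. Compound 3 is estimated at 90%, with a likely range from 68% to 106%.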

Compound 3, a percentage reported as activity, at one concentration (the size of the read-out at that concentration, not a potency): 91%
Beside the measured number, compound 3's estimate is 1 percentage points below it; measured number inside the range.
By their numbers in this assay, from the lowest: compound 1; then compounds 3 and 2 (each within the scatter of the next).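

In this assay, methyl in place of hydrogen on this oxygen gives a number 10 percentage points lower from compound 2 to compound 3 (within the scatter), so turning hydroxy into methoxy here has no effect that can be told apart from the scatter. Among these compounds, compound 3 also gives the first comparison that changes only the group on the amide-type nitrogen: with the methoxy kept, 3,4-dichlorophenyl in place of 3-(trifluoromethyl)phenyl gives a number 12 percentage points higher from compound 1 to compound 3 (beyond the scatter), a modest step that shows this other position can shift the read-out. Nothing available explains either result.

Still open, as far as these compounds go, is whether an ethyl group or a longer chain on this oxygen, or an amine in place of the hydroxy, would shift the number further. From the compounds shown here alone, each result comes from a single concentration, so how potent these compounds are remains unknown.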